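The source may hold more compounds than are shown below. What is called first, only, known or untested is meant among the compounds shown, and "the series" means these compounds.

Working notes on the series

Three compounds of this set have been run in a functional assay on MCF7 cells (Homo sapiens) for inhibition, read by MTT assay, with a stated time of 48 h, tested at 60 ug/mL; a lower number here means less inhibition of growth, a higher number more inhibition of growth at the concentration tested. Compound 1 `O=c1cc(-c2ccccc2)oc2cc(N3COc4c(cccc4[N+](=O)[O-])C3)ccc12` gives 15.7%, the lowest of the three numbers. Compound 2 `O=c1cc(-c2ccccc2)oc2ccc(N3COc4c(Br)cccc4C3)cc12` gives 81.8% and compound 3 `COc1cc2c(c(OC)c1)OCN(c1ccc3c(=O)cc(-c4ccccc4)oc3c1)C2` gives 88.9%, both well beyond the scatter above compound 1, while the two of them lie within the scatter of each other. For the measured compounds named here, none of these three pairs differs in a single place, so no clean step can be drawn among them; compounds 2 and 3 carry other groups on the fused portion of the core and attach to it at another point than compound 1.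

Compound 4 `O=c1cc(-c2ccccc2)oc2cc(N3COc4ccccc4C3)ccc12` is not yet measured. It differs from compound 1 in one place: hydrogen in place of nitro on an aromatic carbon. Going by the values given here, no measured pair shows this change. Given only the low value of compound 1 at 15.7% and the higher numbers of differently substituted compounds 2 and 3, the step of a number 24.3 percentage points higher from compound 1 to compound 4 (beyond the scatter) is expected to be upward, of moderate size, but with wide uncertainty. Compound 4 is therefore estimated at 40%, within a range from 10% to 75%.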

Compound 4, percent growth inhibition at one concentration: 19.3%
Compound 4: the middle estimate sits 20.7 percentage points above what was measured; the measured number falls inside the stated range.
By their numbers in this assay, from the lowest: compounds 1 and 4 (each within the scatter of the next); then compounds 2 and 3 (each within the scatter of the next).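

In this assay, hydrogen in place of nitro on this aromatic carbon is a step of a number 3.6 percentage points higher from compound 1 to compound 4 (within the scatter) and so, at this position of the shared core, the two cannot be told apart. For the compounds shown here, the low number of compound 1 is therefore not tied to its nitro group, something the earlier compounds could not show. Nothing at hand offers an explanation for this step.

Going by these compounds, whether another group on this aromatic carbon, such as an amine or a carboxylic acid, would shift the number remains open; only nitro and hydrogen are compared here. Going by these compounds alone, also open is which structural difference sets compound 2 and compound 3 apart from compound 1 and compound 4, with no single-place step linking them.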